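Carboxyphenyl replaces halophenyl on a cyclopentyl lactam core

The source may hold more compounds than are shown below. What is called first, only, known or untested is meant among the compounds shown, and "the series" means these compounds.

Compound 1 `O=C1c2ccc(OCc3cccc(-c4ccc(Cl)cc4F)c3)cc2CN1C1CCCC1`: "not determined" (no result reported)
Compound 2 `O=C(O)c1cc(-c2cccc(COc3ccc4c(c3)CN(C3CCCC3)C4=O)c2)ccc1O`: 90.1%
Compound 3 `O=C(O)c1cc(-c2cccc(COc3ccc4c(=O)n(C5CCC5)sc4c3)c2)ccc1Cl`: 83%

Three compounds share a benzyloxy-linked aryl group on a bicyclic core and were followed in an assay on HEK293 cells for positive allosteric modulation of metabotropic glutamate receptor 2 (Rattus norvegicus), read by thallium flux; a lower number here means a smaller maximal response, a higher number a larger maximal response. Compound 1 has no single number there, as no result was reported for it, so where it stands cannot be said. Compound 2 reaches 90.1%, and compound 3, which carries a different core and a chloro-substituted carboxyphenyl, reaches 83%; these two values lie within the usual scatter of each other, so no order between them can be read.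

Compound 4 `Cc1ccc(C(=O)O)cc1-c1cccc(COc2ccc3c(c2)CN(C2CCCC2)C3=O)c1` is the next step from compound 1, built on the same core as compound 2. The change is 5-carboxy-2-methylphenyl in place of 4-chloro-2-fluorophenyl on an aromatic carbon. Going by the values given here, since compound 1 has no number, no step size can be computed, and no step between measured compounds is available; the expectation rests on compound 2 and compound 3, whose carboxyl-bearing aryl groups both gave a large maximal response. A comparable value, not a shift beyond the scatter from those two, is expected for compound 4 in this assay.

Compound 4 is estimated to give 86% in this assay, within a range of 62% to 108%.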

Compound 4, largest response reached (reported as percent of maximum), in percent of the reference or control that the assay uses: 80.8%
Compound 4: middle estimate off by 5.2 percentage points, on the high side; the measured number falls inside the stated range.
By their numbers in this assay, from the lowest: compounds 4, 3 and 2 (each within the scatter of the next).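

Going by these compounds alone, with the shared core held fixed, the step of a number 9.3 percentage points lower from compound 2 to compound 4 (within the scatter) in this assay gives the first readable comparison at this aromatic carbon, meta to a large group, where 5-carboxy-2-methylphenyl stands in place of 3-carboxy-4-hydroxyphenyl. The two carboxyl-bearing aryl groups therefore cannot be told apart in maximal response, so this exchange of one substituted carboxyphenyl for another has no effect that can be separated from the scatter. The change from 4-chloro-2-fluorophenyl to 5-carboxy-2-methylphenyl, however, cannot be read, as compound 1 has no number, and no measurement shown here gives a reason for the result.

On these data alone, what the carboxyl-bearing group contributes at this position therefore remains open, since every aryl group with a reported value here carries a carboxylic acid. Whether a primary amide, a methyl ester or a tetrazole in place of that carboxylic acid would give a comparable maximal response on the shared core is also left unanswered, as is whether a plain phenyl would do so.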